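Aryl swap on the aromatic nitrogen of the shared core

The compounds below may be only part of what the source reports. "The series", "measured", "known", "first", "only" and "open" are said of these compounds alone.

Compound 1 `O=C(Nc1cc(-c2ccccc2)nn1-c1ccccc1)c1ccccc1` in an assay on HEK293 cells for displacement of a labelled ligand from metabotropic glutamate receptor 5 (Rattus norvegicus) (a lower number here means a stronger inhibitor, a higher number a weaker inhibitor), gives 4180 nM. Compound 2 `O=C(Nc1cc(-c2ccccc2)nn1-c1ccccn1)c1ccccc1` gives only a limit in this assay, > 10000 nM, so its standing is a bound rather than a number. Within the data shown here, the single measured comparison, an at least 2.3-fold higher number from compound 1 to compound 2 (0.37 log units; beyond the scatter), rests on (the limit of > 10000 nM in this assay, at which 1 of the 2 values shown sits). Compound 3 `O=C(Nc1cc(-c2ccccc2)nn1-c1cccc(Br)c1)c1ccccc1` differs from compound 2 by 3-bromophenyl in place of pyridin-2-yl on an aromatic nitrogen, returning to a carbon-only ring as in compound 1. A step in the other direction, of roughly the size just seen, is expected: an at least 2.5-fold lower number from compound 2 to compound 3 (0.39 log units; beyond the scatter). For compound 3 the estimate is 4000 nM, ranging from 1300 nM to 12000 nM.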

Compound 3, inhibition constant: > 10000 nM
Compound 3 ended at the assay's limit; the forecaster's own chance of this, stated with the estimate: 30%; at least 2.5-fold (0.39 log units) between middle value and limit.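

In this assay, bromo in place of hydrogen on an aromatic carbon gives an at least 2.3-fold higher number from compound 1 to compound 3 (0.37 log units; beyond the scatter). A change on the carbon-only ring therefore also reaches the limit, so this is not confined to the pyridin-2-yl swap. Compound 2 and compound 3 both stand at limits, the step between them cannot be read, and the reading of this position rests on a bound: the limit of > 10000 nM in this assay, at which 2 of the 3 values shown sit.

From the compounds shown here alone, how far 3-bromophenyl and pyridin-2-yl truly differ remains open. Also open, going by these compounds, is how an amine, a methoxy group or a carboxylic acid on this ring would read in this assay.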